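A Hydroxy Group in Place of Phenyl

A few compounds are considered here, and "the series" means these few. Any claim that something is new, unique, unknown or untested is made for them only; others in the source may bear on it.

Of the compounds shown here, three share a common core and have been tested in an ADME assay for pharmacokinetics, read by LC-MS, in phosphate buffer, with a stated time of 120 min, at pH 7.4, tested at 1 uM, in the presence of a further agent that is not named here; on this read-out lower numbers stand for a shorter-lived compound and higher numbers for a longer-lived compound. Compound 1 `O=C(/C=C/CN1CCCCC1)Nc1ccccc1` gives 2.95 h in this assay. For compound 2 `C=C(Cc1ccccc1)C(=O)Nc1ccccc1` the read-out is only a limit of the assay, > 8.53 h. For compound 3 `O=C(/C=C/CC(=O)Nc1ccccc1)Nc1ccccc1` the read-out is likewise only a limit, > 8.53 h. Compound 2 therefore stands at the limit of > 8.53 h in this assay, at which 2 of the 3 values shown sit, so its true half-life is not pinned to a number, only known to lie beyond what the assay reports. For the measured compounds named here, no pair of these three compounds differs in just one place, so no single measured step can be read from them.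

Compound 4 `C=C(CO)C(=O)Nc1ccccc1` has not yet been measured. It differs from compound 2 in one place: hydroxy in place of phenyl on a saturated chain carbon bound to a double-bonded chain carbon. Going by the values given here, with no measured step of this kind to lean on, the expected step from compound 2 to compound 4 in this assay is estimated as an at least 1.4-fold lower number from compound 2 to compound 4 (0.15 log units; that floor lies within the scatter), a modest shortening that may still stay within the scatter. On that basis compound 4 is expected to give about 6 h in this assay, most likely between 2 h and 9 h, with a fair chance that the assay again reports only a limit.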

Compound 4, half-life: > 8.53 h
Compound 4 ended at the assay's limit (the forecaster's own chance of this, stated with the estimate: 45%); middle value at least 1.4-fold (0.15 log units) from the limit.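

Compound 4 gives no new step from compound 2, because both results are only limits of the assay and not numbers, so the size of the change cannot be read: the limit of > 8.53 h in this assay, at which 3 of the 4 values shown sit.

The compounds shown leave open how long compound 2 and compound 4 actually last, and so whether hydroxy in place of phenyl changes the half-life at all.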